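The compounds below may be only part of what the source reports. "The series", "measured", "known", "first", "only" and "open" are said of these compounds alone.

The two measured compounds:

Compound 1, `CC(CC(=O)O)CC(=O)c1c(CCCc2ccccc2)n(C)c2ccc(Cl)cc12`, in a functional assay for antagonist activity at Oxoeicosanoid receptor 1 (Homo sapiens), read by fluorescence and calcium flux, with stated times of 2 min and 1 min (a lower number here means a stronger inhibitor, a higher number a weaker inhibitor), compound 1 gives 223 nM.
Compound 2, `CC(CC(=O)O)CC(=O)c1c(CCCCc2ccccc2)n(C)c2ccc(Cl)cc12`, in this assay compound 2 gives 38 nM.

For the measured compounds named here, compound 2 stands lowest of the two numbers; the only neighbour is compound 1, and the step of a 5.9-fold lower number from compound 1 to compound 2 (0.77 log units; beyond the scatter) is the single change that has been measured. Compound 3, `CC(CC(=O)O)CC(=O)c1c(CCCCCc2ccccc2)n(C)c2ccc(Cl)cc12`, carries the same kind of change one bond further out: benzyl in place of phenyl on a saturated chain carbon, four bonds along the chain from an aromatic carbon. Going by the values given here, only the step from compound 1 to compound 2 bears on it, and that step was of modest size in the lowering direction. One further lengthening of the chain is expected to bring, at most, a smaller further fall, and possibly no change beyond the scatter. For compound 3 the expected step is a 1.5-fold lower number from compound 2 to compound 3 (0.18 log units; within the scatter), giving an estimate of 25 nM, within a range from 8 nM to 80 nM.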

Compound 3, half-maximal inhibitory concentration: 11 nM
Beside the measured number, compound 3's estimate is 2.3-fold (0.36 log units) above it; the measured number falls inside the stated range.
By their numbers in this assay, from the lowest: compound 3; then compound 2; then compound 1.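

In this assay the second extension of the chain, a 3.5-fold lower number from compound 2 to compound 3 (0.54 log units; beyond the scatter), repeats the direction of the first and also lies beyond the scatter, so the fall did not stop after one added carbon. Taken over both extensions, the change amounts to a 20-fold lower number from compound 1 to compound 3 (1.31 log units; beyond the scatter), a large step, and among these three compounds the number falls with each lengthening, with none going against that pattern. Nothing available here explains why the number falls as the chain grows.

For the compounds shown here, whether a longer chain than the one in compound 3 would lower the number further, level off or raise it remains open. Also open, from the compounds shown here alone, is what an amine or a pyridine ring would do at the far end of the chain in place of the phenyl ring.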